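The source may report more compounds than this note shows. Statements on the series, on what has been measured and on what is new or still open speak of the compounds shown alone.

The measured compounds are compound 1 `CCCCCCn1cc(COc2ccc(C(=O)/C=C/c3ccc(OC)cc3)c(O)c2)nn1`, which in an ADME assay on cells (Macrophage) for cytotoxicity, read by resazurin assay, with a stated time of 48 h (a higher number here means that more compound is tolerated, a lower number that less compound is tolerated), gives "not determined" (no result reported); compound 2 `CCCCCCn1cc(COc2ccc(-c3cc(-c4ccccc4)nc(N)n3)c(O)c2)nn1`, which in this assay gives "not determined" (no result reported); and compound 3 `COc1ccc(-c2cc(-c3ccc(OCc4cn(Cc5ccccc5)nn4)cc3O)nc(N)n2)cc1`, which in this assay gives 42700 nM.

Compound 1 therefore stands without a single number in this assay, and only compound 3 shows what a compound of this family tolerates. Compound 4 `CCCCCCn1cc(COc2ccc(C(=O)/C=C/c3ccc(Br)cc3)c(O)c2)nn1` is the next compound to be tested. It differs from compound 1 in one place: bromo in place of methoxy on an aromatic carbon. Within the data shown here, no measured pair shares this change, so the expectation for this assay rests on compound 3 alone. This single change is not expected to move the value beyond the usual scatter. The expected value for compound 4 in this assay is 20000 nM, with a range from 5000 nM to 80000 nM.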

Compound 4, half-maximal cytotoxic concentration: > 100000 nM
Compound 4 ended at the assay's limit (the forecaster's own chance of this, stated with the estimate: 25%); at least 5.0-fold (0.69 log units) between middle value and limit.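

Compound 4 gives > 100000 nM in this assay, which is a limit of the assay and not a number. Among these compounds, no step from compound 1 to compound 4 can be read from this. The compounds shown leave open what bromo in place of methoxy does to tolerance.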